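The compounds below may be only part of what the source reports. "The series", "measured", "known", "first", "only" and "open" are said of these compounds alone.

Measured in an ADME assay on HEK293 cells (Homo sapiens) for cytotoxicity, read by MTT assay, with a stated time of 48 h; a lower number here means a stronger inhibitor, a higher number a weaker inhibitor:

- Compound 1 `Cn1c(N)c(-c2nc3ccccc3[nH]2)c2nc(C#N)c(C#N)nc21`: > 50000 nM (a limit)
- Compound 2 `CCN(CC)CCn1c(N)c(-c2nc3ccccc3[nH]2)c2nc(C#N)c(C#N)nc21`: 12200 nM
- Compound 3 `N#Cc1nc2c(-c3nc4ccccc4[nH]3)c(N)n(CCN3CCCC3)c2nc1C#N`: 18300 nM

Compound 3 stands level with compound 2, since a 1.5-fold higher number from compound 2 to compound 3 (0.18 log units; within the scatter) lies within the scatter. Only these two compounds have actual numbers, as the reading for compound 1 is a limit.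

Compound 4 `CCCn1c(N)c(-c2nc3ccccc3[nH]2)c2nc(C#N)c(C#N)nc21` carries methyl in place of pyrrolidin-1-yl on a saturated chain carbon, two bonds along the chain from an aromatic nitrogen. Read one bond further out, 2-(pyrrolidin-1-yl)ethyl becomes propyl, so compound 4 has a plain chain, as compound 1 does.

Going by the values given here, two measured steps bear on this change. Extending compound 1 gave an at least 2.7-fold lower number from compound 1 to compound 3 (0.43 log units; beyond the scatter) with the pyrrolidine chain and an at least 4.0-fold lower number from compound 1 to compound 2 (0.61 log units; beyond the scatter) with the diethylamino chain. Removing the pyrrolidin-1-yl group should therefore reverse much of that gain in this assay, and the reading may reach the limit. The expected step is a 2.2-fold higher number from compound 3 to compound 4 (0.34 log units; beyond the scatter). Compound 4 is estimated at 40000 nM, within an expected range of 16000 nM to 100000 nM.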

Compound 4, half-maximal inhibitory concentration: > 50000 nM
Compound 4: no number, only a limit (the forecaster's own chance of this, stated with the estimate: 50%); middle value at least 1.2-fold (0.09 log units) from the limit.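

In this assay compound 4 gives > 50000 nM, which is a limit. With methyl in place of the ring amine on the saturated chain carbon, the reading shows an at least 2.7-fold higher number from compound 3 to compound 4 (0.43 log units; beyond the scatter), and with methyl in place of diethylamino it shows an at least 4.0-fold higher number from compound 2 to compound 4 (0.61 log units; beyond the scatter), so a propyl chain does not share the lower numbers of the two chains that end in an amine. The step from compound 1 to compound 4 cannot be read, since both readings are limits: the limit of > 50000 nM in this assay, at which 2 of the 4 values shown sit.

From the compounds shown here alone, how far compound 1 and compound 4 lie past that limit stays open, so the full size of these steps is unknown. Also open, going by these compounds, is whether the amine nitrogen is needed at all, which a chain ending in a hydroxyl group or a morpholin-4-yl group would help to test.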